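Methoxy in Place of Hydroxy: What Compound 4 Might Show

A few compounds are considered here, and "the series" means these few. Any claim that something is new, unique, unknown or untested is made for them only; others in the source may bear on it.

Of the compounds shown here, three built on a shared core have been measured in a functional assay on T47D cells (Homo sapiens) for inhibition, read by sulforhodamine B assay, with a stated time of 48 h, tested at 10 uM; a higher number here means a weaker effect of the compound at the concentration tested, a lower number a stronger effect. Compound 1 `COc1cc(Cl)cc(-c2nn(-c3cccc(NC(=O)c4ccc(Cl)c(Cl)c4)c3)cc2-c2ccncc2)c1` gives 63.2%. Compound 2 `O=C(Nc1cccc(-n2cc(-c3ccncc3)c(-c3cc(O)cc(Cl)c3)n2)c1)Nc1ccc(Cl)c(C(F)(F)F)c1` gives 25%, and compound 3 `O=C(Nc1cccc(-n2cc(-c3ccncc3)c(-c3cc(O)cc(Cl)c3)n2)c1)Nc1ccc(Cl)c(Cl)c1` gives -5.53%. Among these three numbers compound 2 stands second highest: compound 3 is its nearest neighbour, reached by a number 30.5 percentage points lower from compound 2 to compound 3 (beyond the scatter), while compound 1 lies furthest away, with the highest number of the three, beyond the scatter from compound 2.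

Compound 4 `COc1cc(Cl)cc(-c2nn(-c3cccc(NC(=O)Nc4ccc(Cl)c(C(F)(F)F)c4)c3)cc2-c2ccncc2)c1` differs from compound 2 by methyl in place of hydrogen on an oxygen on an aromatic ring, that is, hydroxy becomes methoxy on the 3-chloro-5-hydroxyphenyl group. Among the measured compounds shown here, no measured step follows this change on its own. For the measured compounds named here, the single measured step, a number 30.5 percentage points lower from compound 2 to compound 3 (beyond the scatter), concerns chloro in place of trifluoromethyl elsewhere and does not speak to a methyl on an oxygen. Going by the values given here, compound 1 does carry the methoxy group, but it differs from compound 2 in more than one place, so its value and that of compound 2 show only that the methoxy-bearing compound returned the higher number. The expectation is therefore a modest step upward, a number 13 percentage points higher from compound 2 to compound 4 (beyond the scatter), with wide uncertainty. Compound 4 is expected to give 38% in this assay, within a range from 8% to 70%.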

Compound 4, a percentage reported as activity, at one concentration (the size of the read-out at that concentration, not a potency): 8.1%
Beside the measured number, compound 4's estimate is 29.9 percentage points above it; the range from low to high includes it.
By their numbers in this assay, from the lowest: compound 3; then compound 4; then compound 2; then compound 1.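

In this assay, methyl in place of hydrogen on an oxygen on an aromatic ring now has a measured step of its own, a number 16.9 percentage points lower from compound 2 to compound 4 (beyond the scatter), so at this position, with the rest of the structure held constant, hydroxy to methoxy lowers the number and a methoxy group is compatible with a strong effect at the concentration tested. The high number of compound 1 therefore cannot be read as a mark of the methoxy group, since both compounds in the next step carry it: a number 55.1 percentage points lower from compound 1 to compound 4 (beyond the scatter), where (4-chloro-3-(trifluoromethyl)phenyl)amino stands in place of 3,4-dichlorophenyl on a carbonyl carbon. Nothing available explains the direction or size of either step.

Whether methyl on this oxygen would also lower the number when the 3-chloro-5-hydroxyphenyl group is carried by compound 3 remains open, since the one step shown comes from the trifluoromethyl-bearing compound 2. Also open, going by these compounds, is how a longer chain on the same oxygen, such as ethoxy, or an amine in place of the hydroxy would read in this assay.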